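Second fluoro on the benzyl amide of the chromone core

This account rests on a few compounds, and the source may have more. Where it says the series, first, only, none or still open, it means among the compounds named here.

The series shares the core of compound 1 `COc1ccc2c(=O)c(/C=C/C(=O)Nc3cccc(Cl)c3)coc2c1`, an amide-linked acrylamide with a 3-chlorophenyl on the amide nitrogen. In a functional assay on HeLa cells (Homo sapiens) for inhibition, read by MTT assay, with a stated time of 48 h (a higher number here means a weaker inhibitor, a lower number a stronger inhibitor), compound 1 gives 11900 nM. Compound 2 `COc1ccc2c(=O)c(/C=C/C(=O)NCc3ccccc3)coc2c1` carries a benzyl in its place and gives 33400 nM; the step of a 2.8-fold higher number from compound 1 to compound 2 (0.45 log units; beyond the scatter) is beyond the scatter. Compound 3 `COc1ccc2c(=O)c(/C=C/C(=O)NCc3ccccc3F)coc2c1` carries a 2-fluorobenzyl. For compound 3 this assay returns only a limit, > 100000 nM, so its position is known only as the weakest of the three, at the limit of > 100000 nM in this assay, at which 1 of the 3 values shown sits. The step of an at least 2.9-fold higher number from compound 2 to compound 3 (0.47 log units; beyond the scatter) is therefore a lower bound only, as is an at least 8.4-fold higher number from compound 1 to compound 3 (0.92 log units; beyond the scatter).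

Compound 4 `COc1ccc2c(=O)c(/C=C/C(=O)NCc3ccc(F)cc3F)coc2c1` differs from compound 3 by fluoro in place of hydrogen on an aromatic carbon. Among the measured compounds shown here, the single measured step of the same kind, fluoro in place of hydrogen on an aromatic carbon, is an at least 2.9-fold higher number from compound 2 to compound 3 (0.47 log units; beyond the scatter), and it pointed toward a higher number. With compound 3 already at the limit, a further fluoro is expected to leave compound 4 at or beyond that limit; the expected step is a step that the limit leaves unreadable from compound 3 to compound 4, with the direction resting on the change from compound 2 to compound 3. Compound 4 is estimated at 150000 nM, within 50000 nM to 500000 nM, most likely reported again as a limit.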

Compound 4, half-maximal inhibitory concentration: > 100000 nM
Compound 4: a limit, no number (the forecaster's own chance of this, stated with the estimate: 75%); the middle value lies beyond the limit too.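

In this assay compound 4 gives > 100000 nM, a limit and not a number. A fluoro at this place, para to a large group and meta to a fluoro group, therefore does not bring the 2-fluorobenzyl amide back into the readable range, and both fluorinated benzyl amides remain lower bounds against the two amides with readable values: an at least 2.9-fold higher number from compound 2 to compound 4 (0.47 log units; beyond the scatter) and an at least 8.4-fold higher number from compound 1 to compound 4 (0.92 log units; beyond the scatter). The step between compound 3 and compound 4 cannot be read, and the two compounds now sit together at the limit: the limit of > 100000 nM in this assay, at which 2 of the 4 values shown sit.

From the compounds shown here alone, how far compound 3 and compound 4 lie beyond the limit remains open, as does whether the second fluoro changes the read-out at all. Going by these compounds, it also remains open whether the higher numbers belong to fluoro alone or extend to other groups on the benzyl ring, such as a methoxy or an amine at this same place, or to a longer chain carrying the phenyl ring on the amide nitrogen.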